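Changing the sulfur substituent of compound 2

This account rests on a few compounds, and the source may have more. Where it says the series, first, only, none or still open, it means among the compounds named here.

Measured so far in a functional assay on HeLa cells (Homo sapiens) for inhibition, read by CCK-8 assay, with a stated time of 72 h, tested at 8 uM; on this read-out lower numbers stand for less inhibition of growth and higher numbers for more inhibition of growth at the one concentration tested:
- compound 1 `Cc1cc(C)cc(SCc2ccc(/C=C/C(=O)Nc3ccccc3N)cc2)c1` gives 3.39%
- compound 2 `CCc1ccc(SCc2ccc(C(=O)Nc3ccccc3N)cc2)cc1` gives 71%
- compound 3 `Nc1ccccc1NC(=O)/C=C/c1ccc(CSc2cccc3ccccc23)cc1` gives 22.1%

Compound 2 stands highest of the three, beyond the scatter from both others. Compound 4 `Cc1cc(C)cc(SCc2ccc(C(=O)Nc3ccccc3N)cc2)c1` carries 3,5-dimethylphenyl in place of 4-ethylphenyl on a sulfur. Going by the values given here, the one measured step at this place is a number 18.7 percentage points higher from compound 1 to compound 3 (beyond the scatter), a modest change on a different core. Compound 1 also carries 3,5-dimethylphenyl and gives 3.39% on that other core, so a fall is expected, though that value does not fix its size. The expected step is a number 19 percentage points lower from compound 2 to compound 4 (beyond the scatter) as a moderate estimate. For compound 4 the estimate is 52% in this assay, with an expected range from 20% to 78% at most.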

Compound 4, percent growth inhibition at one concentration: 78.9%
Compound 4: the middle estimate sits 26.9 percentage points below what was measured, outside the stated range (above it).
By their numbers in this assay, from the lowest: compound 1; then compound 3; then compounds 2 and 4 (each within the scatter of the next).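

In this assay the exchange gives a number 7.9 percentage points higher from compound 2 to compound 4 (within the scatter) so on this shared core the sulfur carries 4-ethylphenyl or 3,5-dimethylphenyl with no readable difference. With 3,5-dimethylphenyl on the sulfur, compound 1 gives 3.39% and compound 4 gives 78.9% so the low value of compound 1 does not carry over to the core of compound 4. Nothing available here bears on the reason for this result.

Still open, going by these compounds, is whether a longer chain in place of the ethyl group keeps growth inhibition at this level. The same holds for an amine or a carboxylic acid on the ring attached to the sulfur.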